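The source may report more compounds than this note shows. Statements on the series, on what has been measured and on what is new or still open speak of the compounds shown alone.

Compound 1 `COc1ccc2nccc(C3CN(CCCNCc4cc5ccccc5[nH]4)C(=O)O3)c2c1`: 1580 nM
Compound 2 `COc1ccc2nccc(C3CN(C4CCCCN(Cc5cc6ccccc6[nH]5)C4)C(=O)O3)c2c1`: < 50200 nM
Compound 3 `O=C1OC(c2cccc3ccccc23)CN1C1CCN(Cc2cc3ccccc3[nH]2)CC1`: < 50200 nM

All three were tested in an in vitro functional assay on RBL cells for antagonist activity at C-C chemokine receptor type 8 (Homo sapiens), read by FLIPR and calcium flux; a higher number here means a weaker inhibitor, a lower number a stronger inhibitor. Compound 1 gives 1580 nM. For compound 2 the result is only a limit, < 50200 nM. For compound 3 the result is likewise only a limit, < 50200 nM. Compound 3 therefore stands at the limit rather than at a number, and it shares that position with one other compound, since (the limit of < 50200 nM in this assay, at which 2 of the 3 values shown sit). Only compound 1 shows an actual number in this assay.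

Compound 4 `O=C1OC(c2ccc3ccccc3n2)CN1C1CCN(Cc2cc3ccccc3[nH]2)CC1` has not been measured. It differs from compound 3 in one place: quinolin-2-yl in place of naphthalen-1-yl on a saturated ring carbon. Among the compounds with values here, no step between two measured compounds is recorded, so there is no measured change of this kind to lean on. Because compound 3 gives only a limit < 50200 nM, the starting point of the step is itself uncertain. The expectation for compound 4 is therefore a modest gain beyond the scatter, though a limit again is quite possible. Compound 4 is estimated at 12000 nM, with a range from 1500 nM to 50000 nM. That estimate means an expected step that the limit leaves unreadable from compound 3 to compound 4.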

Compound 4, half-maximal inhibitory concentration: < 50200 nM
Compound 4 gave a limit, no number; the forecaster's own chance of this, stated with the estimate: 40%; the middle value lies beyond the limit too.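

No step can be read between compound 3 and compound 4, because each gives only a limit and no number: the limit of < 50200 nM in this assay, at which 3 of the 4 values shown sit. Whether quinolin-2-yl in place of naphthalen-1-yl changes the result in this assay at all, and in which direction, stays open with the compounds shown.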